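Pyrazolylamino series: cytotoxicity toward gastric epithelial cells

A few compounds are considered here, and "the series" means these few. Any claim that something is new, unique, unknown or untested is made for them only; others in the source may bear on it.

Compound 1 `Cc1cc(Nc2cc(-c3ccccc3)[nH]n2)n2ncnc2n1` and compound 2 `Cc1cc(Nc2cc(-c3ccccc3)[nH]n2)n2nc(SCc3cccc(Br)c3)nc2n1` share the core, compound 2 carrying (3-bromobenzyl)sulfanyl in place of hydrogen on an aromatic carbon. In an ADME assay on GES1 cells (Homo sapiens) for inhibition, read by MTT assay, with a stated time of 72 h (on this read-out lower numbers stand for stronger inhibition and higher numbers for weaker inhibition), compound 1 gives only a limit, > 50000 nM. Compound 2 likewise gives a limit, > 50000 nM. Between them lies a step that the two limits leave unreadable from compound 1 to compound 2, since both sit at the limit of > 50000 nM in this assay, at which 2 of the 3 values shown sit. For the measured compounds named here, compound 3 `Cc1cc(Nc2ccn(Cc3nc(C)c4ccccc4n3)n2)n2nc(SCc3ccc(Br)cc3)nc2n1` is the one compound with a number in this assay, where compound 3 gives 36800 nM. Compound 4 `Cc1cc(Nc2ccn(Cc3ccc(C(F)(F)F)cc3)n2)n2nc(SCc3ccc(Br)cc3)nc2n1` differs from compound 3 by 4-(trifluoromethyl)phenyl in place of 4-methylquinazolin-2-yl on a saturated chain carbon bound to an aromatic nitrogen. Going by the values given here, no measured step touches this position; the single measured step lies elsewhere and is unreadable. The step of a 1.0-fold higher number from compound 3 to compound 4 (0.01 log units; within the scatter) is expected to stay within the scatter. Compound 4 is estimated at 38000 nM, between 15000 nM and 90000 nM.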

Compound 4, half-maximal inhibitory concentration: 30200 nM
Beside the measured number, compound 4's estimate is 1.3-fold (0.10 log units) above it; measured number inside the range.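

In this assay, for the compounds shown here, the change at this position gives a 1.2-fold lower number from compound 3 to compound 4 (0.09 log units; within the scatter) and is the first readable step, since the step from compound 1 to compound 2 cannot be read. On the saturated chain carbon bound to an aromatic nitrogen, 4-(trifluoromethyl)phenyl and 4-methylquinazolin-2-yl therefore read alike, although one ring and both ring nitrogens leave with the change. No measured property shown bears on this result. On these data alone, it remains open whether a carboxylic acid or an amine on that carbon would also read alike.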